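A Hydroxy and Methoxy Arrangement Not Yet Measured

The source may hold more compounds than are shown below. What is called first, only, known or untested is meant among the compounds shown, and "the series" means these compounds.

In a functional assay on SW480 cells (Homo sapiens) for antiproliferative activity, read by sulforhodamine B assay, with a stated time of 48 h (on this read-out lower numbers stand for stronger inhibition and higher numbers for weaker inhibition), compound 1 (`COc1ccc(OC)c(/C=C/C(=O)C(=Cc2ccc(O)c(OC)c2)C(=O)/C=C/c2cc(OC)ccc2OC)c1`) gives 410 nM and compound 2 (`COc1ccc(OC)c(/C=C/C(=O)C(=Cc2ccc(O)c(F)c2)C(=O)/C=C/c2cc(OC)ccc2OC)c1`) gives 510 nM, so compound 2 stands level with compound 1 within the scatter. Compound 3 (`COc1ccc(OC)c(/C=C/C(=O)C(=Cc2ccc(OC)c(O)c2)C(=O)/C=C/c2cc(OC)ccc2OC)c1`) differs from compound 2 as follows: 3-hydroxy-4-methoxyphenyl in place of 3-fluoro-4-hydroxyphenyl on a double-bonded chain carbon bound to a double-bonded chain carbon. Among the compounds with values here, the one measured step on this aryl group, a 1.2-fold higher number from compound 1 to compound 2 (0.09 log units; within the scatter), stayed within the scatter, although no measured compound carries 3-hydroxy-4-methoxyphenyl. The expected change is therefore small, an estimated 1.1-fold lower number from compound 2 to compound 3 (0.05 log units; within the scatter), with nothing beyond the scatter anticipated in this assay. For compound 3 the estimate is 450 nM, with an expected range of 200 nM to 1100 nM.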

Compound 3, half-maximal inhibitory concentration: 1120 nM
For compound 3 the middle estimate is 2.5-fold (0.40 log units) below the measured one, and the stated range ends below it.
By their numbers in this assay, from the lowest: compounds 1 and 2 (each within the scatter of the next); then compound 3.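

In this assay this aryl group proved sensitive to where its hydroxy and methoxy stand: moving to 3-hydroxy-4-methoxyphenyl gives a 2.7-fold higher number from compound 1 to compound 3 (0.44 log units; beyond the scatter) and a 2.2-fold higher number from compound 2 to compound 3 (0.34 log units; beyond the scatter), both beyond the scatter. Within the data shown here, the earlier fluoro for methoxy step had stayed within the scatter, so this is the first change on the group to register. No measurement shown here explains the difference. The compounds shown leave open whether an amine or a carboxylic acid in place of the hydroxy on this aryl group would keep the number of compound 1.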